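Hydroxy in Place of Methoxy: Expected Cost to Growth Inhibition

The source may report more compounds than this note shows. Statements on the series, on what has been measured and on what is new or still open speak of the compounds shown alone.

Compound 2 `COc1cc(-c2nn(-c3cccc(NC(=O)Nc4cc(C(F)(F)F)cc(C(F)(F)F)c4)c3)cc2-c2ccncc2)ccc1Cl` holds the lowest number of the two compounds that give a number in a functional assay on IGROV-1 cells (Homo sapiens) for inhibition, read by sulforhodamine B assay, with a stated time of 48 h (a higher number here means a weaker inhibitor of growth, a lower number a stronger inhibitor of growth), where compound 2 gives 2190 nM. Its nearest neighbour is compound 3 `COc1cc(-c2nn(-c3cccc(NC(=O)Nc4cccc(C(F)(F)F)c4)c3)cc2-c2ccncc2)ccc1Cl`, which in this assay gives 3110 nM; the step of a 1.4-fold higher number from compound 2 to compound 3 (0.15 log units; within the scatter) lies within the scatter, so the two cannot be ranked against each other. Compound 1 `O=C(Nc1cccc(-n2cc(-c3ccncc3)c(-c3ccc(Cl)c(O)c3)n2)c1)Nc1cccc(C(F)(F)F)c1` reaches only a limit of this assay, giving > 32500 nM. Compound 4 `O=C(Nc1cccc(-n2cc(-c3ccncc3)c(-c3ccc(Cl)c(O)c3)n2)c1)Nc1cc(C(F)(F)F)cc(C(F)(F)F)c1` has not yet been measured. It differs from compound 2 by hydrogen in place of methyl on an oxygen on an aromatic ring. Among the measured compounds shown here, one measured step bears directly on this change, and it runs in the opposite direction: an at least 10-fold lower number from compound 1 to compound 3 (1.01 log units; beyond the scatter), a large drop in the number, with compound 1 sitting at the limit of > 32500 nM in this assay, at which 1 of the 3 values shown sits. Undoing that same change on compound 2 is therefore expected to raise the number by a similarly large amount, well beyond the scatter, and may carry compound 4 up to the same limit where compound 1 sits. For compound 4 the expected step is a 14-fold higher number from compound 2 to compound 4 (1.14 log units; beyond the scatter). Compound 4 is estimated at 30000 nM in this assay, with a range from 10000 nM to 100000 nM.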

Compound 4, concentration for total growth inhibition: 3550 nM
Estimate against measurement, compound 4: 8.5-fold (0.93 log units) above; the whole stated range lies above it.
By their numbers in this assay, from the lowest: compounds 2, 3 and 4 (each within the scatter of the next). At a limit, above all of these: compound 1.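

The methoxy group on the 4-chloro-3-methoxyphenyl ring turns out not to be needed in every case in this assay: on the core with two trifluoromethyl groups, hydroxy in its place gives a 1.6-fold higher number from compound 2 to compound 4 (0.21 log units; within the scatter), so the two cannot be ranked. With hydroxy in place, the second trifluoromethyl group now makes a clear difference, giving an at least 9.1-fold lower number from compound 1 to compound 4 (0.96 log units; beyond the scatter), and this differs from what the same group does when methoxy is present: the same change on two cores in this assay, a 1.4-fold higher number (0.15 log units; within the scatter) from compound 2 to compound 3 and an at least 9.1-fold higher number (0.96 log units; beyond the scatter) from compound 4 to compound 1, at least 6.4-fold (0.80 log units) apart, beyond the scatter of two such steps. Read the other way round, the effect of replacing methoxy with hydroxy depends on whether the second trifluoromethyl group is there, so neither change can be judged on its own: the same change on two cores in this assay, an at least 10-fold lower number (1.01 log units; beyond the scatter) from compound 1 to compound 3 and a 1.6-fold lower number (0.21 log units; within the scatter) from compound 4 to compound 2, at least 6.4-fold (0.80 log units) apart, beyond the scatter of two such steps.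

As far as these compounds go, compound 1 gives > 32500 nM, which is a limit, so the full size of its steps stays unknown. The compounds shown also leave open whether this dependence would hold with an ethoxy group or an amine on that ring carbon in place of methoxy or hydroxy, or with a chlorine in place of the second trifluoromethyl group.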